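This account rests on a few compounds, and the source may have more. Where it says the series, first, only, none or still open, it means among the compounds named here.

Three compounds that share one core have been run in an assay on SH-EP1 cells for agonist activity at Neuronal acetylcholine receptor; alpha4/beta2 (Homo sapiens), read by FLIPR and calcium flux; a lower number here means a smaller maximal response, a higher number a larger maximal response. Compound 1 `CCCC(=O)N1CC2CC(C1)N2` gives 110%, the highest of the three. Compound 3 `O=C(C1CC=CC1)N1CC2CC(C1)N2` gives 95%, which lies beyond the scatter below compound 1, and compound 2 `O=C(C1CCCC1)N1CC2CC(C1)N2` gives 68%, the furthest from compound 1. No pair among these differs in a single place, so no one-step change has yet been measured in this assay. Compound 4 `O=C([C@@H]1C[C@H]1F)N1CC2CC(C1)N2` differs from compound 1 by 2-fluorocyclopropyl in place of propyl on a carbonyl carbon. For the step of a number 15 percentage points lower from compound 1 to compound 4 (beyond the scatter) a modest decrease is expected, close to the edge of the scatter. Compound 4 is therefore estimated at 95% in this assay, with a range from 70% to 115%.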

Compound 4, largest response reached (Emax), in percent of the reference or control that the assay uses: 110%
Compound 4: middle estimate off by 15 percentage points, on the low side; the range from low to high includes it.
By their numbers in this assay, from the lowest: compound 2; then compound 3; then compounds 1 and 4 (each within the scatter of the next).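

In this assay, going by these compounds alone, the change to 2-fluorocyclopropyl in place of propyl on a carbonyl carbon gives no change at the digits printed from compound 1 to compound 4 (within the scatter) as the only one-place step read so far. This position therefore accepts a fluorine-bearing three-membered ring with 2 defined stereocentres in place of an open chain, with the maximal response held within the scatter. Nothing at hand explains this result.

The compounds shown leave open what the fluorine and the ring each contribute, since plain cyclopropyl is not among them. They also do not tell how the other stereoisomers, a longer chain or an amine would fare here.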